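Swapping the aryl amide for a methylisoxazole in a kinase series

The source may hold more compounds than are shown below. What is called first, only, known or untested is meant among the compounds shown, and "the series" means these compounds.

Three amides sharing one core have been tested in an assay on isolated protein for inhibition of Rho-associated protein kinase 2 (Homo sapiens), read by scintillation counting, radiometric assay and 33P incorporation, with a stated time of 40 min, in the presence of a further agent that is not named here; on this read-out lower numbers stand for stronger inhibition and higher numbers for weaker inhibition. Compound 1 `N#Cc1ccc(C(=O)Nc2cccc(NC(=O)COc3ccc4c(=O)ccoc4c3)c2)cc1` gives 15 nM, compound 2 `COc1ccc(C(=O)Nc2cccc(NC(=O)COc3ccc4c(=O)ccoc4c3)c2)cc1` gives 7 nM, and compound 3 `O=C(COc1ccc2c(=O)ccoc2c1)Nc1cccc(NC(=O)c2ccc(OC(F)(F)F)cc2)c1` gives 77 nM. Compound 3 therefore stands highest of the three, with the step of a 5.1-fold higher number from compound 1 to compound 3 (0.71 log units; beyond the scatter) and the step of an 11-fold higher number from compound 2 to compound 3 (1.04 log units; beyond the scatter) both showing that the trifluoromethoxy-bearing aryl amide is the weakest member so far. Compound 4 `Cc1cc(C(=O)Nc2cccc(NC(=O)COc3ccc4c(=O)ccoc4c3)c2)no1` differs from compound 3 in the same part of the molecule: 5-methyl-1,2-oxazol-3-yl in place of 4-(trifluoromethoxy)phenyl on a carbonyl carbon. For the measured compounds named here, no measured step replaces a phenyl ring by a five-membered heteroaromatic ring, so the two steps into compound 3 are the only guide; they show that other groups on this carbonyl carbon give lower numbers than compound 3, by modest to large margins. On that basis compound 4 is expected to return toward the numbers of compound 1 and compound 2, with a step of about a 2.6-fold lower number from compound 3 to compound 4 (0.41 log units; beyond the scatter) in this assay. The estimate for compound 4 is 30 nM, within a range of 8 nM to 120 nM.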

Compound 4, half-maximal inhibitory concentration: 5 nM
The estimate for compound 4 lay 6.0-fold (0.78 log units) above the measured number; the whole stated range lies above it.
By their numbers in this assay, from the lowest: compounds 4 and 2 (each within the scatter of the next); then compound 1; then compound 3.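

In this assay, the phenyl ring on this carbonyl carbon proves dispensable: 5-methyl-1,2-oxazol-3-yl gives a 15-fold lower number from compound 3 to compound 4 (1.19 log units; beyond the scatter) and a 3.0-fold lower number from compound 1 to compound 4 (0.48 log units; beyond the scatter), while a 1.4-fold lower number from compound 2 to compound 4 (0.15 log units; within the scatter) leaves the pair level. The earlier compounds shown here varied only the group on a phenyl ring, whereas this change shows that a five-membered aromatic ring with 2 hetero atoms and fewer heavy atoms can keep the number as low as that of the 4-methoxyphenyl amide. Nothing available here accounts for this result.

The compounds shown leave open whether the methyl group on the new ring contributes at all, or whether another five-membered ring, such as a thiazole or a pyrazole, would read the same. They also leave open how an amine or a carboxylic acid in place of that methyl group would read.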